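The compounds below may be only part of what the source reports. "The series", "measured", "known", "first", "only" and "open" are said of these compounds alone.

In a functional assay on MDA-MB-231 cells (Homo sapiens) for cytotoxicity, read by MTT assay, with a stated time of 48 h (a higher number here means a weaker inhibitor, a lower number a stronger inhibitor), compound 3 `Cc1cccc(NC(=O)NCCCCC(c2ccc(F)cc2)c2ccc(F)cc2)c1` gives > 20000 nM, which is a limit and not a number. Compound 1 `O=C(NCCCCC(c1ccc(F)cc1)c1ccc(F)cc1)Nc1ccc(I)cc1` gives 11800 nM, and compound 2 `O=C(NCCCCC(c1ccc(F)cc1)c1ccc(F)cc1)Nc1cccc([N+](=O)[O-])c1` gives 3790 nM. Compound 4 `O=C(NCCCCC(c1ccc(F)cc1)c1ccc(F)cc1)Nc1ccc(Cl)c([N+](=O)[O-])c1` follows from compound 3 by 4-chloro-3-nitrophenyl in place of 3-methylphenyl on an amide-type nitrogen, with 4-chloro-3-nitrophenyl in place of 3-methylphenyl on an amide-type nitrogen. The closest measured change is an at least 5.2-fold higher number from compound 2 to compound 3 (0.72 log units; beyond the scatter), with methyl in place of nitro. Read backwards, it points to a lower number for a nitro-bearing compound. a 3.1-fold lower number from compound 1 to compound 2 (0.49 log units; beyond the scatter) also favours nitro, while an at least 1.6-fold higher number from compound 1 to compound 3 (0.22 log units; that floor lies within the scatter) stays inside the scatter at its floor. Going by the values given here, no measured step isolates the added chloro. The expected change is an at least 5.7-fold lower number from compound 3 to compound 4 (0.75 log units; beyond the scatter), similar in size and direction to the reverse of the nitro step. For compound 4 the estimated value is 3500 nM, with an expected range of 1200 nM to 10000 nM.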

Compound 4, half-maximal inhibitory concentration: 4060 nM
For compound 4 the middle estimate is 1.2-fold (0.06 log units) below the measured one, and the stated range covers the measured number.
By their numbers in this assay, from the lowest: compounds 2 and 4 (each within the scatter of the next); then compound 1. At a limit, above all of these: compound 3.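

In this assay, the chloro of the 4-chloro-3-nitrophenyl group on the amide-type nitrogen leaves the read-out level with the 3-nitrophenyl group, at a 1.1-fold higher number from compound 2 to compound 4 (0.03 log units; within the scatter). The advantage over the 4-iodophenyl group persists with this group, at a 2.9-fold lower number from compound 1 to compound 4 (0.46 log units; beyond the scatter), and the step of an at least 4.9-fold lower number from compound 3 to compound 4 (0.69 log units; beyond the scatter) gives only a floor. Compound 3 stands at a limit and not a number: the limit of > 20000 nM in this assay, at which 1 of the 4 values shown sits.

Open, as far as these compounds go, is whether an amine or a carboxylic acid in place of the nitro would hold this level. From the compounds shown here alone, the effect of a longer chain in the shared core also remains open.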